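Phenyl on the aromatic nitrogen: expected half-life of compound 4

A few compounds are considered here, and "the series" means these few. Any claim that something is new, unique, unknown or untested is made for them only; others in the source may bear on it.

Measured so far:
compound 1 `COc1cccc(CNC(=O)c2c[nH]c3cc(-c4cn[nH]c4)ccc23)c1` gives 0.417 h
compound 2 `COc1cccc(CN(C)C(=O)c2c[nH]c3cc(-c4cn[nH]c4)ccc23)c1` gives 0.217 h
compound 3 `COc1cccc(CN(CCCN(C)C)C(=O)c2cn(C)c3cc(-c4cn[nH]c4)ccc23)c1` gives 0.233 h

All three were tested in an in vitro ADME assay on microsomes from liver (Homo sapiens) for metabolic stability; a higher number here means that the compound lasts longer, a lower number that the compound disappears faster. Compound 1 has the highest of the three numbers, but its nearest neighbour, compound 3, and its furthest, compound 2, both lie within the scatter of it, so no order can be read among them. Going by the values given here, the one step that changes a single place, a 1.9-fold lower number from compound 1 to compound 2 (0.28 log units; within the scatter), is within the scatter. Compound 3 also carries a methyl on the aromatic nitrogen, but it differs from compound 1 in a second place as well, so its value alone cannot be tied to that position.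

Compound 4 `COc1cccc(CNC(=O)c2cn(-c3ccccc3)c3cc(-c4cn[nH]c4)ccc23)c1` differs from compound 1 by phenyl in place of hydrogen on an aromatic nitrogen. Among the compounds with values here, no measured step addresses this change directly; the only single-place step, from compound 1 to compound 2, was within the scatter. The step from compound 1 to compound 4 is therefore expected to be small, a 1.4-fold lower number from compound 1 to compound 4 (0.14 log units; within the scatter), with the uncertainty wide. Compound 4 is estimated at 0.3 h in this assay, between 0.12 h and 0.7 h.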

Compound 4, half-life: 0.167 h
The estimate for compound 4 lay 1.8-fold (0.25 log units) above the measured number; measured number inside the range.
By their numbers in this assay, from the lowest: compounds 4, 2, 3 and 1 (each within the scatter of the next, the first and the last beyond it).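

With phenyl in place of hydrogen on the aromatic nitrogen, this assay gives a 2.5-fold lower number from compound 1 to compound 4 (0.40 log units; beyond the scatter), so this position can register a change beyond the scatter, though only modestly. The earlier single-place step, a 1.9-fold lower number from compound 1 to compound 2 (0.28 log units; within the scatter), concerned an amide-type nitrogen and stayed within the scatter, which makes this the first step among the compounds shown that can be read as a real shortening of the half-life. Nothing available here accounts for this step.

Going by these compounds, whether methyl alone on the aromatic nitrogen of compound 1 would shift the half-life remains open: compound 3 carries that methyl only together with a second change. Also open, on these data alone, is what a benzyl group, or a phenyl bearing a carboxylic acid, would do at this nitrogen.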